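The compounds below may be only part of what the source reports. "The series", "measured", "known", "first", "only" and "open" are said of these compounds alone.

Compound 1 `CC#C[C@@H](CC(=O)O)c1ccc(OC[C@H]2COc3ccc(F)cc3O2)cc1`, compound 2 `CC#C[C@@H](CC(=O)O)c1ccc(OC[C@H]2COc3ccc(OC)cc3O2)cc1` and compound 3 `CC#C[C@@H](CC(=O)O)c1ccc(OC[C@H]2COc3ccc(S(C)(=O)=O)cc3O2)cc1` share one core and differ only in a single group on an aromatic carbon. In a functional assay on HEK293 cells for agonist activity at Free fatty acid receptor 1 (Homo sapiens), read by fluorescence and calcium flux, with a stated time of 10 min (a lower number here means that less compound is needed, a higher number that more compound is needed for the effect), compound 1 gives 210 nM, compound 2 gives 130 nM and compound 3 gives 27200 nM, the highest of the three numbers. The steps of a 130-fold higher number from compound 1 to compound 3 (2.11 log units; beyond the scatter) and a 210-fold higher number from compound 2 to compound 3 (2.32 log units; beyond the scatter) show that the methylsulfonyl group goes with a far larger number than fluoro or methoxy. Compound 4 `CC#C[C@@H](CC(=O)O)c1ccc(OC[C@H]2COc3ccc(CO)cc3O2)cc1` differs from compound 3 by hydroxymethyl in place of methylsulfonyl on an aromatic carbon. Among the measured compounds shown here, no measured step involves hydroxymethyl, so the known steps only suggest that removing methylsulfonyl should lower the number, with the size uncertain. Compound 4 is therefore expected to show the step of a 45-fold lower number from compound 3 to compound 4 (1.66 log units; beyond the scatter), an estimated 600 nM with a range from 100 nM to 4000 nM.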

Compound 4, half-maximal effective concentration: > 30000 nM
Compound 4 ended at the assay's limit (the forecaster's own chance of this, stated with the estimate: 5%); middle value at least 50-fold (1.69 log units) from the limit.
By their numbers in this assay, from the lowest: compounds 2 and 1 (each within the scatter of the next); then compound 3. At a limit, above all of these: compound 4.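

In this assay compound 4 reads > 30000 nM, which is a limit of the assay and not a number. The steps of an at least 230-fold higher number from compound 2 to compound 4 (2.36 log units; beyond the scatter) and an at least 140-fold higher number from compound 1 to compound 4 (2.15 log units; beyond the scatter) show that hydroxymethyl, like methylsulfonyl, goes with far larger numbers at this position than methoxy or fluoro. The step of an at least 1.1-fold higher number from compound 3 to compound 4 (0.04 log units; that floor lies within the scatter) allows no ranking of the two, but replacing methylsulfonyl with the smaller hydroxymethyl brought no return to low numbers.

As far as these compounds go, whether an amine, a carboxylic acid or a plain methyl here would keep the numbers low stays open. So does the true value of compound 4.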